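The source may report more compounds than this note shows. Statements on the series, on what has been measured and on what is new or still open speak of the compounds shown alone.

In an ADME assay on microsomes from liver (Homo sapiens) for metabolic stability, read by LC-MS, with a stated time of 10 min (a lower number here means that less of the compound is left, a higher number that more of the compound is left), measured so far:
- compound 1 `CN(C[C@H]1Cc2c(cccc2N2CCN3CCC[C@H]3C2)CN1)[C@H]1CCCc2cccnc21`: 36.6%
- compound 2 `CN(C[C@H]1Cc2c(cccc2N2CCN(Cc3ccccn3)CC2)CN1)[C@H]1CCCc2cccnc21`: 4.2%
- compound 3 `CN(C[C@H]1Cc2c(cccc2N2CCN(c3ncccn3)CC2)CN1)[C@H]1CCCc2cccnc21`: 35.5%

Compound 3 at 35.5% is within the scatter of compound 1 at 36.6%, and its value is well over that of compound 2.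

The next compound is compound 4 `CCN1CCN(c2cccc3c2C[C@H](CN(C)[C@H]2CCCc4cccnc42)NC3)CC1`. The change is ethyl in place of pyrimidin-2-yl on an amine nitrogen in a ring.

Going by the values given here, one measured step bears on this place, a number 31.3 percentage points higher from compound 2 to compound 3 (beyond the scatter), a large step with pyrimidin-2-yl in place of (pyridin-2-yl)methyl. Ethyl resembles (pyridin-2-yl)methyl only in being joined through a saturated carbon, and it brings no ring. Compound 1 at 36.6% also has only saturated carbon on the matching nitrogen, which argues against a fall as large as the measured step. With so few compounds, the range stays wide.

A modest fall is expected, an estimated a number 8.5 percentage points lower from compound 3 to compound 4 (within the scatter). For compound 4 the expected value is 27%, with an estimated range of 10% to 45%.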

Compound 4, percent of the compound remaining: 0%
Compound 4: middle estimate off by 27 percentage points, on the high side; measured number below the stated range.
By their numbers in this assay, from the lowest: compounds 4 and 2 (each within the scatter of the next); then compounds 3 and 1 (each within the scatter of the next).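

In this assay, a ring on the substituent is not what separates the low numbers at this amine nitrogen: ethyl carries no ring, yet the step of a number 35.5 percentage points lower from compound 3 to compound 4 (beyond the scatter) is large, while the step of a number 4.2 percentage points lower from compound 2 to compound 4 (within the scatter) leaves ethyl and (pyridin-2-yl)methyl within the scatter of each other. Saturated carbon on this nitrogen does not by itself give a low number, and compound 1 goes against that reading, with the large step of a number 36.6 percentage points lower from compound 1 to compound 4 (beyond the scatter). Nothing available here explains these differences.

Going by these compounds, it remains open whether the higher number of compound 3 is particular to pyrimidin-2-yl or also holds for another group joined directly through an aromatic carbon, such as phenyl. An acetyl on the same nitrogen would show whether a non-aromatic group without a saturated linking carbon behaves the same way.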